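The source may hold more compounds than are shown below. What is called first, only, known or untested is meant among the compounds shown, and "the series" means these compounds.

In a functional assay on HT-29 cells (Homo sapiens) for antiproliferative activity, read by MTT assay, with a stated time of 96 h (a lower number here means a stronger inhibitor, a higher number a weaker inhibitor), compound 1 `CCCc1ccc(N2C(=O)NC3(CSC4=C3C(=O)c3ncccc3C4=O)C2=O)cc1` gives 1 nM, the lowest number among the three compounds measured. Compound 2 `O=C1NN(c2ccccc2)C(=O)C2(CSC3=C2C(=O)c2ncccc2C3=O)N1` gives 550 nM, a gap from compound 1 well beyond the usual scatter. Compound 3 `O=C1NC(=O)C2(CSC3=C2C(=O)c2ncccc2C3=O)N1` gives 190 nM; 180 nM; 190 nM (3 entries), and its repeated entries agree closely while lying far from the number for compound 1.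

Compound 4 `CCCCc1ccc(N2C(=O)NC3(CSC4=C3C(=O)c3ncccc3C4=O)C2=O)cc1` keeps the core of compound 1 and extends its chain from propyl to butyl: methyl in place of hydrogen on a saturated chain carbon, three bonds along the chain from an aromatic carbon. Among the compounds with values here, no two measured compounds differ in one place, so no measured step shows what such a change does here. In this assay, no step beyond the scatter is expected for this single added methyl. That expectation rests only on the small size of the change and on compound 1, at 1 nM, and it remains uncertain. The estimated change is a 1.5-fold higher number from compound 1 to compound 4 (0.18 log units; within the scatter). Compound 4 is expected to give 1.5 nM, with an estimated range of 0.4 nM to 8 nM.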

Compound 4, half-maximal inhibitory concentration: 50 nM
Compound 4: the middle estimate sits 33-fold (1.52 log units) below what was measured; measured number above the stated range.
By their numbers in this assay, from the lowest: compound 1; then compound 4; then compound 2.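

The step shows that this chain position is highly sensitive: in this assay, one added methyl on a saturated chain carbon, three bonds along the chain from an aromatic carbon, gives a 50-fold higher number from compound 1 to compound 4 (1.70 log units; beyond the scatter). Within the data shown here, no earlier pair differed in one place, and this first such pair shows that the shared core with an alkyl chain does not by itself secure the lowest number, since the change from propyl to butyl alone moves it well beyond the scatter. The entries of this assay also sit close together where a compound was measured repeatedly: the several entries of compound 3 in this assay, 190 nM; 180 nM; 190 nM (3 entries)

As far as these compounds go, a single step gives no trend, so whether an ethyl or a pentyl chain would continue this rise or break it stays open. Also open, from the compounds shown here alone, are what lies behind the step and how an amine or a carboxylic acid on this chain would read.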